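Cyclopentyl to Isopropyl on Two Related Cores

The compounds below may be only part of what the source reports. "The series", "measured", "known", "first", "only" and "open" are said of these compounds alone.

Compound 1 `Cc1c(OCCCCOc2ccc(C(=O)O)cc2F)ccc(C(=O)CC2CCCC2)c1O` and compound 3 `Cc1c(OCCCCOc2ccc(C(=O)O)cc2F)ccc(C(=O)CC(C)C)c1O` share one core and differ by isopropyl in place of cyclopentyl on a saturated chain carbon bound to a carbonyl carbon. In an assay on HEK293 cells for positive allosteric modulation of metabotropic glutamate receptor 3 (Rattus norvegicus), read by thallium flux, with a stated time of 2.5 min (a lower number here means a smaller maximal response, a higher number a larger maximal response), compound 1 gives 31.2%, while compound 3 gives 67.7%, a step of a number 36.5 percentage points higher from compound 1 to compound 3 (beyond the scatter). Compound 2 `Cc1c(OCCCCOc2ccc(C(=O)O)cc2)ccc(C(=O)CC2CCCC2)c1C` carries another core; the difference between the two cores is not broken down here. In this assay compound 2 gives 12.2%, the lowest of the three values and beyond the scatter from both others. Compound 4 `Cc1c(OCCCCOc2ccc(C(=O)O)cc2)ccc(C(=O)CC(C)C)c1C` differs from compound 2 by isopropyl in place of cyclopentyl on a saturated chain carbon bound to a carbonyl carbon, the same change seen between compound 1 and compound 3. Because the step of a number 36.5 percentage points higher from compound 1 to compound 3 (beyond the scatter) was large, a rise is expected here too, though it rests on a single pair measured on a different core. The expected step for compound 4 is a number 22.8 percentage points higher from compound 2 to compound 4 (beyond the scatter). Compound 4 is thus estimated at 35%, between 12% and 60%.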

Compound 4, largest response reached (reported as percent of maximum), in percent of the reference or control that the assay uses: 16.6%
Compound 4: the middle estimate sits 18.4 percentage points above what was measured, within the range that was stated.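

In this assay, isopropyl in place of cyclopentyl gives a step of a number 4.4 percentage points higher from compound 2 to compound 4 (within the scatter). Set beside the earlier step, the change does not carry over in size from one core to the other: the same change on two cores in this assay, a number 36.5 percentage points higher (beyond the scatter) from compound 1 to compound 3 and a number 4.4 percentage points higher (within the scatter) from compound 2 to compound 4, 32.1 percentage points apart, beyond the scatter of two such steps. This shows that, for these two pairs, the result of the change depends on the core that carries it, but with one pair per core it does not show which difference between the cores matters, and the two cores are not broken down here. The compounds shown leave open how a longer chain or an amine on a saturated chain carbon bound to a carbonyl carbon would behave on either core.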